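Swapping an aryl ring for a benzyloxy group

The compounds below may be only part of what the source reports. "The series", "measured", "known", "first", "only" and "open" are said of these compounds alone.

Of the compounds shown here, three sharing one core have been tested in a functional assay on HEK293 cells for agonist activity at G-protein coupled receptor 39 (Homo sapiens), read by scintillation proximity assay and inositol phosphate accumulation, with a stated time of 75 min, in the presence of a further agent that is not named here; a higher number here means that more compound is needed for the effect, a lower number that less compound is needed. Compound 1, `Cc1nn(-c2ncnc3nc[nH]c23)c2c1C(c1ccc(F)cc1Cl)CC(=O)N2`, gives 9 nM. Compound 2, `CCC(C(=O)NC1CC(=O)Nc2c1c(C)nn2-c1ncnc2nc[nH]c12)c1ccccc1`, gives 5 nM, and compound 3, `Cc1nn(-c2ncnc3nc[nH]c23)c2c1C(C(=O)NCc1ccc(F)cc1)CC(=O)N2`, gives 4 nM. Compound 1 has the highest number of the three: its gap to compound 2 lies within the usual scatter of such measurements, while its gap to compound 3 lies beyond it, so compound 3 needs somewhat less compound than compound 1 for the same effect.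

The next compound, compound 4, `Cc1nn(-c2ncnc3nc[nH]c23)c2c1C(OCc1ccc(Cl)cc1Cl)CC(=O)N2`, has not yet been measured in this assay. It differs from compound 1 in one place: (2,4-dichlorobenzyl)oxy in place of 2-chloro-4-fluorophenyl on a saturated ring carbon.

For the measured compounds named here, no measured pair shows this kind of exchange, so the size of the step is open. Compounds 1, 2 and 3 carry rather different groups on this saturated ring carbon and still give numbers close to one another, which suggests that this position accepts change without a large shift. The step of a 1.7-fold higher number from compound 1 to compound 4 (0.22 log units; within the scatter) is therefore expected to be small, at most a modest rise in the number. For compound 4 the estimate is 15 nM, with a range from 4 nM to 60 nM.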

Compound 4, half-maximal effective concentration: 4 nM
Beside the measured number, compound 4's estimate is 3.8-fold (0.57 log units) above it; the range from low to high includes it.
By their numbers in this assay, from the lowest: compounds 3, 4, 2 and 1 (each within the scatter of the next, the first and the last beyond it).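

In this assay, for the compounds shown here, exchanging 2-chloro-4-fluorophenyl for (2,4-dichlorobenzyl)oxy gives a 2.3-fold lower number from compound 1 to compound 4 (0.35 log units; beyond the scatter) as the first step at this saturated ring carbon that can be read as a change in one place. The entering group has 10 heavy atoms against 8 for the group that leaves, and it carries 1 hydrogen-bond acceptor where the leaving group has none, yet less compound is needed for the effect, not more. So, at least for this pair, a larger group holding an oxygen is accepted at this position, although the modest size of the step means that this single pair shows only a small gain.

Nothing measured here tells what lies behind this step. Several features change together in this exchange, so the separate shares of the oxygen, the added carbon and the second chlorine in place of fluorine stay open, as does how an amine or a carboxylic acid on the benzyl ring, or a longer chain leading to that ring, would move the number.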